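The compounds below may be only part of what the source reports. "The series", "measured", "known", "first", "only" and "open" are said of these compounds alone.

Working notes on the hydroxyphenyl series.

Four compounds are under consideration. For compound 1 `Oc1ccc(-c2cc(-c3cccnc3)nc(-c3ccccc3Cl)c2)cc1` the entry in a functional assay on HCT-15 cells (Homo sapiens) for cytotoxicity, read by CCK-8 assay and cell counting, with a stated time of 2 days (on this read-out higher numbers stand for weaker inhibition and lower numbers for stronger inhibition), reads "not determined" (no result reported), so no number is available for it. Compound 2 `Oc1ccc(-c2cc(-c3ccsc3)nc(-c3cccc(Cl)c3)c2)cc1` gives 5760 nM in this assay. Compound 3 `Oc1cccc(-c2cc(-c3ccsc3)nc(-c3ccccc3Cl)c2)c1` gives 2500 nM in this assay, the lower of the two numbers available; the gap to compound 2 lies beyond the usual scatter, so on the present numbers compound 3 is the stronger of the two measured entries. Among the compounds with values here, no step between measured compounds that differ in a single place is available, so the effect of any one change has not yet been isolated.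

Compound 4 `Oc1ccc(-c2cc(-c3ccsc3)nc(-c3ccccc3Cl)c2)cc1` is the next compound to be measured in this assay. Its relation to compound 3 is 4-hydroxyphenyl in place of 3-hydroxyphenyl on an aromatic carbon. The two compounds are built from the same atoms, joined differently: the hydroxyl sits at a different position of the phenyl ring attached opposite the ring nitrogen. Compound 2 also carries a 4-hydroxyphenyl group, but with a 3-chlorophenyl group rather than a 2-chlorophenyl group, so it does not settle the matter.

The expected step of a 1.4-fold higher number from compound 3 to compound 4 (0.15 log units; within the scatter) is small, with a slight lean toward a weaker number, and may well fall within the scatter. For compound 4 the estimate in this assay is 3500 nM, with a range from 1500 nM to 8000 nM.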

Compound 4, half-maximal inhibitory concentration: 5830 nM
The estimate for compound 4 lay 1.7-fold (0.22 log units) below the measured number; low and high end bracket the measured number.
By their numbers in this assay, from the lowest: compound 3; then compounds 2 and 4 (each within the scatter of the next).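

Within the data shown here, the move from 3-hydroxyphenyl to 4-hydroxyphenyl, on the aromatic carbon opposite the ring nitrogen, is the first single change isolated in this assay and gives a 2.3-fold higher number from compound 3 to compound 4 (0.37 log units; beyond the scatter), so with the 2-chlorophenyl and thiophen-3-yl groups held fixed, the placement of the hydroxyl on this phenyl ring registers beyond the scatter. With 4-hydroxyphenyl held fixed, 2-chlorophenyl in place of 3-chlorophenyl gives a 1.0-fold higher number from compound 2 to compound 4 (0.01 log units; within the scatter), so this shift of the chlorine leaves the number within the scatter for this pair. No measurement is at hand that could explain the effect of the hydroxyl placement.

Going by these compounds, it remains open whether the same hydroxyl step would appear with a 3-chlorophenyl group in place of the 2-chlorophenyl group, since the present step rests on a single pair. Also open, on these data alone, is whether a methoxy group or an amine in place of the hydroxyl, at either ring position, would keep the lower number of compound 3 or lose it.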